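Removing a bromine from the core of compound 3

A few compounds are considered here, and "the series" means these few. Any claim that something is new, unique, unknown or untested is made for them only; others in the source may bear on it.

Of the compounds shown here, three have been measured so far in an ADME assay on HEK-293T cells (Homo sapiens) for cytotoxicity, read by luminescence and CellTiter-Glo, with a stated time of 24 h (a lower number here means that less compound is tolerated, a higher number that more compound is tolerated), all of them sharing the same propylamide-bearing piperidine amide and a methoxybenzyl group on the core. Compound 1 has the structure `CCCNC(=O)C1CCN(C(=O)c2cc3[nH]cnc3n2Cc2ccc(OC)cc2)CC1`. In this assay compound 1 gives > 100000 nM, which is a limit of the assay and not a number. Compound 2, with the structure `CCCNC(=O)C1CCN(C(=O)c2cc3sc(-c4ccccc4)nc3n2Cc2ccc(OC)cc2)CC1`, gives a number: in this assay compound 2 shows 22900 nM. Compound 3 has the structure `CCCNC(=O)C1CCN(C(=O)c2cc3cc(Br)ccc3n2Cc2ccc(OC)cc2)CC1`. In this assay compound 3 gives > 100000 nM, again a limit of the assay rather than a number. Compound 3 therefore stands at the limit of > 100000 nM in this assay, at which 2 of the 3 values shown sit, together with compound 1, while compound 2 alone gives a measurable value.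

The next compound, compound 4, has the structure `CCCNC(=O)C1CCN(C(=O)c2cc3ccccc3n2Cc2ccc(OC)cc2)CC1`. It differs from compound 3 in one place: hydrogen in place of bromo on an aromatic carbon. Among the compounds with values here, no step between two measured compounds is available to show what this kind of change does in this assay, so the expectation rests on where compound 3 stands. The step that the limit leaves unreadable from compound 3 to compound 4 is expected to be none beyond the scatter, in either direction. Compound 4 is thus estimated to give 150000 nM in this assay, with a range from 60000 nM to 400000 nM, and it is expected that the assay will most likely report only a limit again.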

Compound 4, half-maximal cytotoxic concentration: 26000 nM
Compound 4: the middle estimate sits 5.8-fold (0.76 log units) above what was measured; the whole stated range lies above it.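

Within the data shown here, this is the first step that changes one place only, and it shows that this position matters in this assay. Putting hydrogen in place of bromo on this aromatic carbon gives an at least 3.8-fold lower number from compound 3 to compound 4 (0.58 log units; beyond the scatter), so the cells tolerate less of the compound without the bromo group, and the value moves from a limit to a measurable number. The step can only be given as a minimum, and its true size remains unknown, because compound 3 sits at a limit of the assay rather than at a number: the limit of > 100000 nM in this assay, at which 2 of the 4 values shown sit.

The compounds shown leave open whether tolerance depends on bromine itself or whether any group on this carbon would have a similar effect, which a chloro, fluoro, methyl or methoxy group at the same place could begin to answer. They also leave open whether an amine or a carboxylic acid there would keep the number high, and whether the same change from bromo to hydrogen would give a step of similar size on a different core.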